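One added methoxy on compound 1

This account rests on a few compounds, and the source may have more. Where it says the series, first, only, none or still open, it means among the compounds named here.

For the measured compounds named here, in a functional assay on A549 cells (Homo sapiens) for cytotoxicity, read by MTT assay, with a stated time of 72 h (a lower number here means a stronger inhibitor, a higher number a weaker inhibitor), compound 1 `COc1cccc(/C=C2\CCC/C(=C\c3cccc(OC)c3OC)C2=O)c1` gives 16400 nM, the only actual number in the set. Compound 2 `COc1cccc(/C=C2\CCC/C(=C\c3ccc(Cl)cc3Cl)C2=O)c1OC` reports only a limit, > 20000 nM. Compound 3 `COc1cccc(/C=C2\CCC/C(=C\c3ccc(Cl)c(Cl)c3)C2=O)c1OC` also reports only a limit, > 20000 nM.

Compound 4 `COc1ccc(/C=C2\CCC/C(=C\c3cccc(OC)c3OC)C2=O)cc1OC` differs from compound 1 by one change: methoxy in place of hydrogen on an aromatic carbon. The change falls on the 3-methoxyphenyl group, and the nearest evidence comes from replacing that whole group: an at least 1.2-fold higher number from compound 1 to compound 2 (0.08 log units; that floor lies within the scatter), and an at least 1.2-fold higher number from compound 1 to compound 3 (0.08 log units; that floor lies within the scatter). Both floors lie within the scatter, and neither step is the same change. No step beyond the scatter is therefore expected in this assay. The expected step is a 1.2-fold lower number from compound 1 to compound 4 (0.07 log units; within the scatter). For compound 4 the estimated value is 14000 nM, with an expected range of 6000 nM to 30000 nM.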

Compound 4, half-maximal inhibitory concentration: 14400 nM
Beside the measured number, compound 4's estimate is 1.0-fold (0.01 log units) below it, and the stated range covers the measured number.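

For the compounds shown here, the step of a 1.1-fold lower number from compound 1 to compound 4 (0.06 log units; within the scatter) in this assay is the first with actual numbers at both ends. It shows that methoxy in place of hydrogen, on the aromatic carbon ortho to a methoxy group and para to a large group, leaves the number within the scatter. The step between the two dichlorophenyl compounds cannot be read, and the steps to them give only floors: the limit of > 20000 nM in this assay, at which 2 of the 4 values shown sit.

As far as these compounds go, what an amine or a carboxylic acid on this carbon would do stays open. So does whether a longer chain in place of methoxy would give a step beyond the scatter.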